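A few compounds are considered here, and "the series" means these few. Any claim that something is new, unique, unknown or untested is made for them only; others in the source may bear on it.

Working notes on the series, read in a functional assay on SW480 cells (Homo sapiens) for cytotoxicity, read by MTT assay, with a stated time of 48 h; on this read-out higher numbers stand for weaker inhibition and lower numbers for stronger inhibition. Compound 1 (`CCOC(=O)[C@]1(C(=O)Nc2ccccc2)C[C@H]1c1cc(OC)c(OC)c(OC)c1`) reads > 100000 nM, a limit of the assay. Compound 2 (`CCOC(=O)C1(C(=O)Nc2ccccc2Cl)CC1c1cc(OC)c(OC)c(OC)c1`) gives 27200 nM; 66700 nM (2 entries). Compound 3 (`CCOC(=O)[C@]1(C(=O)Nc2ccccc2Cl)C[C@@H]1c1cc(OC)c(OC)c(OC)c1`) reads > 100000 nM, also a limit. Compound 3 therefore has no number of its own, and among the values shown only compound 2 has numbers.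

Compound 4 (`CCOC(=O)[C@]1(C(=O)Nc2ccccc2Cl)C[C@H]1c1cc(OC)c(OC)c(OC)c1`) is the next to be read, and its relation to compound 3 is simple: the two compounds have the same atoms and bonds and differ only in configuration as drawn: 1 of 2 stereo elements differ; a stereocentre at a saturated ring carbon is drawn R in compound 3 and S in compound 4.

Among the measured compounds shown here, no measured step gives a size for this change. The expectation rests on compound 2 at 27200 nM; 66700 nM (2 entries), set against compound 3, with one further point to keep in view: the fact that one of compounds 2 and 3 is drawn with a defined configuration and the other without, at the place where they differ. A modest move towards stronger inhibition in this assay is expected, with a real chance that compound 4 also stays at the limit. The expected step is an at least 1.8-fold lower number from compound 3 to compound 4 (0.25 log units; that floor lies within the scatter). For compound 4 the estimated value is 55000 nM, with an expected range of 20000 nM to 120000 nM.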

Compound 4, half-maximal inhibitory concentration: 25600 nM
Compound 4: the middle estimate sits 2.1-fold (0.33 log units) above what was measured; the measured number falls inside the stated range.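

In this assay, the configuration drawn at this saturated ring carbon now has a measured size, with S in place of R giving an at least 3.9-fold lower number from compound 3 to compound 4 (0.59 log units; beyond the scatter): the fact that compounds 3 and 4 differ only in the configuration as drawn With this configuration kept, chloro in place of hydrogen on an aromatic carbon gives an at least 3.9-fold lower number from compound 1 to compound 4 (0.59 log units; beyond the scatter), and in both steps the starting compound sits at a limit of the assay, so each size is only a floor. Compound 4 also sets a single drawn configuration beside compound 2, whose entries carry no defined configuration at that place: the fact that one of compounds 2 and 4 is drawn with a defined configuration and the other without, at the place where they differ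

On these data alone, how far the drop in the number depends on chloro itself remains open, since a methoxy group or an amine at that place would test it at the same configuration. As far as these compounds go, whether the ethyl ester can give way to a carboxylic acid or a primary amide also remains open.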